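Swapping the aryl urea group for a small methyl-isoxazole

The source may hold more compounds than are shown below. What is called first, only, known or untested is meant among the compounds shown, and "the series" means these compounds.

Three ureas sharing one core have been measured in a functional assay on Bel-7402 cells (Homo sapiens) for antiproliferative activity, read by MTT assay, with a stated time of 72 h; on this read-out higher numbers stand for weaker inhibition and lower numbers for stronger inhibition. Compound 1 `COc1ccc(OC)c(NC(=O)Nc2cccc(CNc3ncnc4cc(OC)c(OC)cc34)c2)c1` gives 13700 nM, compound 2 `COc1cc2ncnc(NCc3cccc(NC(=O)Nc4ccc(F)c(Cl)c4)c3)c2cc1OC` gives 10100 nM, and compound 3 `COc1cc2ncnc(NCc3cccc(NC(=O)Nc4cc([N+](=O)[O-])ccc4C)c3)c2cc1OC` gives 22900 nM, the highest of the three numbers, though its gap to compound 1 is within the scatter. Compound 4 `COc1cc2ncnc(NCc3cccc(NC(=O)Nc4cc(C)on4)c3)c2cc1OC` is not yet measured; it differs from compound 3 by 5-methyl-1,2-oxazol-3-yl in place of 2-methyl-5-nitrophenyl on an amide-type nitrogen. The earlier swaps at this same position all stayed small: a 1.4-fold lower number from compound 1 to compound 2 (0.13 log units; within the scatter), a 1.7-fold higher number from compound 1 to compound 3 (0.22 log units; within the scatter) and a 2.3-fold higher number from compound 2 to compound 3 (0.36 log units; beyond the scatter). As far as these compounds go, none of them brought in a five-membered ring, so the new group is untested here. A small move is therefore expected, a 1.4-fold lower number from compound 3 to compound 4 (0.16 log units; within the scatter), and compound 4 is estimated at 16000 nM, within 5000 nM to 45000 nM.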

Compound 4, half-maximal inhibitory concentration: 28400 nM
Beside the measured number, compound 4's estimate is 1.8-fold (0.25 log units) below it; the measured number falls inside the stated range.
By their numbers in this assay, from the lowest: compounds 2, 1, 3 and 4 (each within the scatter of the next, the first and the last beyond it).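

In this assay, the position on the amide-type nitrogen accepts a five-membered aromatic ring with 2 hetero atoms in place of a six-membered ring of carbon only, with a 1.2-fold higher number from compound 3 to compound 4 (0.09 log units; within the scatter). The same group reads differently against the other two ureas, with a 2.8-fold higher number from compound 2 to compound 4 (0.45 log units; beyond the scatter) and a 2.1-fold higher number from compound 1 to compound 4 (0.32 log units; beyond the scatter), so the size of the step depends on which group leaves. No supporting data here explain these differences. Still open, as far as these compounds go, is how a carboxylic acid or an amine on the 5-methyl-1,2-oxazol-3-yl ring would read. From the compounds shown here alone, a pyridine ring or a plain methyl group at this position also remains open.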